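The source may hold more compounds than are shown below. What is called first, only, known or untested is meant among the compounds shown, and "the series" means these compounds.

Of the compounds shown here, three of a shared core have been tested in a functional assay on MCF7 cells (Homo sapiens) for cytotoxicity, read by CCK-8 assay, with a stated time of 72 h; a lower number here means a stronger inhibitor, a higher number a weaker inhibitor. Compound 1 `C=CCn1c(=O)/c(=C\c2cccc(C)c2)[nH]c(=O)/c1=C\c1ccccc1OC` gives 20700 nM. Compound 3 `C=CCn1c(=O)/c(=C\c2cccc(Cl)c2)[nH]c(=O)/c1=C\c1ccccc1OC` gives 5200 nM, and compound 2 `COc1ccccc1/C=c1\c(=O)[nH]/c(=C/c2cccc(Cl)c2Cl)c(=O)n1C` gives 200 nM. Compound 3 therefore stands second highest of the three numbers: its nearest neighbour is compound 1, whose number is higher, and its furthest is compound 2, whose number is far lower.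

Among the compounds with values here, the one change that has been followed within this set is the step of a 4.0-fold lower number from compound 1 to compound 3 (0.60 log units; beyond the scatter), in which the methyl group gave way to chloro on an aromatic carbon.

Compound 4 `C=CCn1c(=O)/c(=C\c2cccc(Cl)c2Cl)[nH]c(=O)/c1=C\c1ccccc1OC` has not yet been measured. It differs from compound 3 by chloro in place of hydrogen on an aromatic carbon. Within the data shown here, no measured pair shows exactly this change, so the expectation must rest on two indirect hints: compound 3 itself, at 5200 nM, and compound 2, which carries the same 2,3-dichlorophenyl group and gives 200 nM, though compound 2 also differs from compound 4 at the other nitrogen substituent. Both hints point the same way, so a lower number is expected for compound 4 in this assay, but with wide uncertainty. The estimate for compound 4 is 1500 nM, with a range from 400 nM to 6000 nM, corresponding to an expected step of a 3.5-fold lower number from compound 3 to compound 4 (0.54 log units; beyond the scatter).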

Compound 4, half-maximal inhibitory concentration: 2100 nM
Estimate against measurement, compound 4: 1.4-fold (0.15 log units) below, and the stated range covers the measured number.
By their numbers in this assay, from the lowest: compound 2; then compound 4; then compound 3; then compound 1.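

Within the data shown here, a second chloro, ortho to a chloro group on the six-membered aromatic ring, continues the trend that the earlier chloro for methyl swap began: in this assay, going from 3-chlorophenyl to 2,3-dichlorophenyl gives a 2.5-fold lower number from compound 3 to compound 4 (0.39 log units; beyond the scatter), the first direct reading of this change and a modest one. Taken whole, the replacement of 3-methylphenyl by 2,3-dichlorophenyl gives a 9.9-fold lower number from compound 1 to compound 4 (0.99 log units; beyond the scatter), so this aromatic ring tolerates substitution and responds to it, with the lower numbers marking stronger inhibitors. Among these compounds, with the dichlorophenyl group now held constant, the nitrogen substituent can also be read on its own for the first time: the vinyl in place of hydrogen on the saturated chain carbon gives an 11-fold higher number from compound 2 to compound 4 (1.02 log units; beyond the scatter), a step rated large where the added chloro is rated modest.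

The compounds shown leave open whether groups such as trifluoromethyl, nitrile or an amine on this aromatic ring would follow the chloro steps, and whether an ethyl or a longer chain on the nitrogen would sit nearer compound 2 or compound 4. Nothing measured here accounts for the size of any of these steps.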